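This account rests on a few compounds, and the source may have more. Where it says the series, first, only, none or still open, it means among the compounds named here.

Measured compounds:
compound 1, `COc1cc2ncnc(NCc3cccc(NC(=O)Nc4ccccc4)c3)c2cc1OC`, 19700 nM
compound 2, `COc1cc2ncnc(NCc3cccc(NC(=O)Nc4ccc(C(C)(C)C)cc4)c3)c2cc1OC`, 6850 nM
compound 3, `COc1cc2ncnc(NCc3cccc(NC(=O)Nc4ccc(Cl)cc4)c3)c2cc1OC`, > 50000 nM

In a functional assay on HepG2 cells (Homo sapiens) for antiproliferative activity, read by MTT assay (a lower number here means a stronger inhibitor, a higher number a weaker inhibitor), compound 1 gives 19700 nM and compound 2 gives 6850 nM. For compound 3 the assay reports only a limit, > 50000 nM, so compound 3 stands at the weak end of the measured set without an exact number. Compound 4, `COc1cc2ncnc(NCc3cccc(NC(=O)Nc4cccc(C(F)(F)F)c4)c3)c2cc1OC`, differs from compound 3 by 3-(trifluoromethyl)phenyl in place of 4-chlorophenyl on an amide-type nitrogen. The measured steps that bear on this change are a 2.9-fold lower number from compound 1 to compound 2 (0.46 log units; beyond the scatter) and an at least 2.5-fold higher number from compound 1 to compound 3 (0.40 log units; beyond the scatter), which together make an at least 7.2-fold higher number from compound 2 to compound 3 (0.86 log units; beyond the scatter); none of them involves a trifluoromethyl group, so the direction for compound 4 is uncertain. Compound 4 is expected to move back into the measurable range, by about an at least 1.6-fold lower number from compound 3 to compound 4 (0.22 log units; that floor lies within the scatter). The estimate for compound 4 is 30000 nM, between 8000 nM and 60000 nM.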

Compound 4, half-maximal inhibitory concentration: 34200 nM
Compound 4: middle estimate off by 1.1-fold (0.06 log units), on the low side; measured number inside the range.
By their numbers in this assay, from the lowest: compound 2; then compounds 1 and 4 (each within the scatter of the next). At a limit, above all of these: compound 3.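

In this assay, trifluoromethyl in place of hydrogen gives a 1.7-fold higher number from compound 1 to compound 4 (0.24 log units; within the scatter), so compound 4, unlike compound 3, keeps a measurable number and cannot be told apart from compound 1. Against the tert-butyl group, the new group gives a 5.0-fold higher number from compound 2 to compound 4 (0.70 log units; beyond the scatter), which leaves compound 2 ahead of compound 4. Compound 3 has only a limit, so an at least 1.4-fold lower number from compound 3 to compound 4 (0.16 log units; that floor lies within the scatter) is a floor, because the step starts from that limit: the limit of > 50000 nM in this assay, at which 1 of the 4 values shown sits.

Trifluoromethyl appears only as 3-(trifluoromethyl)phenyl, and chloro and tert-butyl only as 4-chlorophenyl and 4-(tert-butyl)phenyl, so the effects of group and place cannot be separated. From the compounds shown here alone, how a methoxy group or an amine on this phenyl would read also remains open.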